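Furan-3-yl for ethynyl on the methylamino core

The source may hold more compounds than are shown below. What is called first, only, known or untested is meant among the compounds shown, and "the series" means these compounds.

Compounds measured so far:
compound 1 `C#Cc1cn([C@@H]2O[C@H](CO)[C@@H](O)[C@H]2O)c2ncnc(N(C)C)c12` — 240 nM
compound 2 `C#Cc1cn([C@@H]2O[C@H](CO)[C@@H](O)[C@H]2O)c2ncnc(NC)c12` — 18500 nM
compound 3 `C#Cc1cn([C@@H]2O[C@H](CO)[C@@H](O)[C@H]2O)c2ncnc(SC)c12` — 110 nM

In a functional assay on CEM-DNR-bulk cells (Homo sapiens), read by MTT assay, with a stated time of 72 h (a higher number here means a weaker inhibitor, a lower number a stronger inhibitor), compound 2 gives the highest number of the three; the step of a 77-fold higher number from compound 1 to compound 2 (1.89 log units; beyond the scatter) and the step of a 170-fold lower number from compound 2 to compound 3 (2.23 log units; beyond the scatter) both lie beyond the scatter, so compound 2 is the weakest inhibitor of those measured. Compound 4 `CNc1ncnc2c1c(-c1ccoc1)cn2[C@@H]1O[C@H](CO)[C@@H](O)[C@H]1O` is not yet measured. It differs from compound 2 by furan-3-yl in place of ethynyl on an aromatic carbon.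

Both measured steps that involve compound 2 alter the group on the other aromatic carbon of the core: a 77-fold higher number from compound 1 to compound 2 (1.89 log units; beyond the scatter) and a 170-fold lower number from compound 2 to compound 3 (2.23 log units; beyond the scatter) are large, but neither touches the ethynyl, and the shown step a 2.2-fold lower number from compound 1 to compound 3 (0.34 log units; beyond the scatter) is modest and likewise elsewhere. For the measured compounds named here, no measured step therefore bears directly on the exchange of ethynyl for furan-3-yl, and no direction can be read from the data. The expected step in this assay is a 1.5-fold lower number from compound 2 to compound 4 (0.19 log units; within the scatter), which is within or near the scatter. For compound 4 the estimated value is 12000 nM, with a range from 2500 nM to 60000 nM.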

Compound 4, half-maximal inhibitory concentration: > 20000 nM
Compound 4 gave a limit, no number; the forecaster's own chance of this, stated with the estimate: 10%; middle value at least 1.6-fold (0.22 log units) away from the limit.
By their numbers in this assay, from the lowest: compound 3; then compound 1; then compound 2. At a limit, above all of these: compound 4.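

In this assay compound 4 gives > 20000 nM, which is a limit of the assay and not a number. This is the only step shown at the position two ring bonds from the ring nitrogen, and an at least 1.0-fold higher number from compound 2 to compound 4 (0.03 log units; that floor lies within the scatter) gives only a floor, so the size of the change from ethynyl to furan-3-yl remains unresolved. Even so, the methylamino core shows no gain from furan-3-yl: in this assay compound 2 gives 18500 nM and a clearly lower number for compound 4 would have been readable.

Going by these compounds, it stays open whether furan-3-yl would be tolerated on the dimethylamino or methylsulfanyl cores, whose numbers lie far from the limit and could show a change in either direction. On these data alone, how an amine, a carboxylic acid or a simple methyl would behave in place of ethynyl also stays open.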